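The source may report more compounds than this note shows. Statements on the series, on what has been measured and on what is new or still open speak of the compounds shown alone.

Measured in a functional assay on CaEs17 cells (Homo sapiens) for cytotoxicity, read by MTT assay, with a stated time of 72 h; on this read-out higher numbers stand for weaker inhibition and lower numbers for stronger inhibition:
- compound 1 `C=C1C(=O)[C@@]23C(=O)OC[C@]4([C@@H](OC(C)=O)CCC(C)(C)[C@H]4C=O)[C@@H]2CC[C@@H]1[C@H]3O`: 72600 nM
- compound 2 `C=C1C(=O)[C@@]23C(=O)OC[C@]4(C(=O)CCC(C)(C)[C@H]4C=O)[C@@H]2CC[C@@H]1[C@H]3OC(C)=O`: 1350 nM
- compound 3 `C=C1C(=O)[C@@]23C(=O)OC[C@]4(C(=O)CCC(C)(C)[C@H]4C=O)[C@@H]2CC[C@@H]1[C@H]3OC(=O)c1ccc(C)cc1`: 1050 nM

Compound 3 has the lowest of the three numbers, but it is not separated from compound 2, as the two values lie within the scatter of each other. Compound 1 stands far higher than both.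

Compound 4 `C=C1C(=O)[C@@]23C(=O)OC[C@]4(C(=O)CCC(C)(C)[C@H]4C=O)[C@@H]2CC[C@@H]1[C@H]3OC(=O)c1ccccc1Cl` departs from compound 3 in one place: 2-chlorophenyl in place of 4-methylphenyl on a carbonyl carbon. The group changes, but the carbonyl carbon that carries it stays the same. Within the data shown here, only one measured step bears on this place: a 1.3-fold lower number from compound 2 to compound 3 (0.11 log units; within the scatter). Even that exchange of methyl for an aromatic ring left the number within the scatter. Among the measured compounds shown here, compound 1 differs from the others in more than one place, so it offers no comparable step. For the measured compounds named here, no measured compound carries chlorine, so this support is indirect, and no shift beyond the scatter is expected in this assay.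

The expected change is a 1.0-fold higher number from compound 3 to compound 4 (0.02 log units; within the scatter). Compound 4 is estimated at 1100 nM, with an expected range of 500 nM to 2500 nM.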

Compound 4, half-maximal inhibitory concentration: 2010 nM
Compound 4: the middle estimate sits 1.8-fold (0.26 log units) below what was measured, within the range that was stated.
By their numbers in this assay, from the lowest: compounds 3, 2 and 4 (each within the scatter of the next); then compound 1.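

In this assay, among these compounds, the place on the carbonyl carbon now carries a chlorine-bearing ring for the first time, and 2-chlorophenyl in place of 4-methylphenyl gives a 1.9-fold higher number from compound 3 to compound 4 (0.28 log units; within the scatter), while 2-chlorophenyl in place of methyl gives a 1.5-fold higher number from compound 2 to compound 4 (0.17 log units; within the scatter). Methyl, 4-methylphenyl and 2-chlorophenyl thus all lie within the scatter of one another here, so among compounds 2, 3 and 4 neither the aromatic ring nor the chlorine separates one compound from another. No measurement offered here accounts for how closely these three groups agree.

Still open, going by these compounds, is whether a group of another kind on this carbonyl carbon, such as an amine-bearing chain or a carboxylic acid, would move the number beyond the scatter. The large gap to compound 1 also remains unassigned, since compound 1 differs from the others in more than one place.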